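This account rests on a few compounds, and the source may have more. Where it says the series, first, only, none or still open, it means among the compounds named here.

Compound 1 `C=CC1=C(C(=O)NCc2ccc(Cl)cc2)C(c2ccc(OC)c(OC)c2)OC1` — > 100000 nM 
Compound 2 `C=CC1=C(C(=O)Nc2ccccc2OC)C(c2ccc(F)cc2)OC1` — > 100000 nM 
Compound 3 `C=CC1=C(C(=O)Nc2cccc(C)c2)C(c2ccc(F)cc2)OC1` — "not active" (no number reported) 

Of the compounds shown here, three sharing the same core have been tested in a functional assay on HeLa cells (Homo sapiens) for cytotoxicity, read by MTT assay, with a stated time of 24 h; a lower number here means a stronger inhibitor, a higher number a weaker inhibitor. For compound 1 the figure of > 100000 nM is a limit of the assay and not a number. For compound 2 the figure of > 100000 nM is likewise a limit. Compound 3 has no single number at all; it is recorded as "not active" (no number reported). Where compound 3 stands can therefore be said only loosely: the two other values shown sit at the limit of > 100000 nM in this assay, at which 2 of the 3 values shown sit, and compound 3 is reported as inactive without a figure, so it is not distinguished from its companions by anything in the data.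

The next compound, compound 4 `C=CC1=C(C(=O)NCCCCC)C(c2ccc(F)cc2)OC1`, differs from compound 3 in one place: pentyl in place of 3-methylphenyl on an amide-type nitrogen. Among the compounds with values here, no step between measured compounds exists here, so there is nothing to gauge the effect of this change against. Given that every compound shown is inactive or at the limit, the expectation for compound 4 in this assay is no step beyond the scatter, and most likely another limit rather than a number. The estimate for compound 4 is 100000 nM, with a range from 30000 nM to 300000 nM.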

Compound 4, half-maximal inhibitory concentration: > 100000 nM
Compound 4: a limit, no number; the forecaster's own chance of this, stated with the estimate: 75%; the middle value sits exactly at the limit.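

In this assay compound 4 gives > 100000 nM, which is a limit of the assay and not a number. Within the data shown here, no step to compound 4 can be read from compound 2, also recorded at a limit, or from compound 3, recorded without a number. The compounds shown leave open whether any group on the amide-type nitrogen gives a measurable value in this assay.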